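From 4-Fluorobenzyl to 2-Fluorobenzyl on a Shared Core

This account rests on a few compounds, and the source may have more. Where it says the series, first, only, none or still open, it means among the compounds named here.

Three compounds have so far been taken to an ADME assay on HEK293 cells (Homo sapiens) for cytotoxicity, read by MTT assay, with a stated time of 24 h (on this read-out lower numbers stand for stronger inhibition and higher numbers for weaker inhibition), and the record they leave is thin. In this test compound 1 `Cc1ccc(/C=C2\CN(C(=S)SCc3cn(Cc4ccccc4F)nn3)C/C(=C\c3ccc(C)cc3)C2=O)cc1` gives "not determined" (no result reported). Compound 2 `COc1ccc(/C=C2\CN(Cc3cn(Cc4ccc(F)cc4)nn3)C/C(=C\c3ccc(OC)cc3)C2=O)cc1` gives "not determined" (no result reported), so it stands without a number of its own. Compound 3 `Cc1ccc(/C=C2\CN(Cc3cn(Cc4ccccc4F)nn3)C/C(=C\c3ccc(C)cc3)C2=O)cc1` gives > 100000 nM, which is a limit of the assay and not a number. The evidence thus comes down to the limit of > 100000 nM in this assay, at which 1 of the 3 values shown sits.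

The next structure is compound 4 `COc1ccc(/C=C2\CN(Cc3cn(Cc4ccccc4F)nn3)C/C(=C\c3ccc(OC)cc3)C2=O)cc1`, which has yet to be measured. The change is 2-fluorophenyl in place of 4-fluorophenyl on a saturated chain carbon bound to an aromatic nitrogen, or 4-fluorobenzyl to 2-fluorobenzyl when cut one bond further out. With no number for compound 2, the size of this step cannot be read from measurements. In this assay no step beyond the usual scatter is expected from this swap, in either direction. The expectation of weak inhibition rests on the limit for compound 3 at > 100000 nM. For compound 4 the estimated value is 100000 nM, with an expected range from 40000 nM to 200000 nM.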

Compound 4, half-maximal inhibitory concentration: > 100000 nM
Compound 4 was reported as a limit; the forecaster's own chance of this, stated with the estimate: 65%; the middle value lies on the limit itself.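

In this assay compound 4 gives > 100000 nM, which is a limit of the assay and not a number. Within the data shown here, compound 2 has no number of its own, so no step between compound 2 and compound 4 can be read. The compounds shown leave open whether 4-fluorobenzyl to 2-fluorobenzyl changes the result at all, and the record so far comes down to this: the limit of > 100000 nM in this assay, at which 2 of the 4 values shown sit.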